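A few compounds are considered here, and "the series" means these few. Any claim that something is new, unique, unknown or untested is made for them only; others in the source may bear on it.

Within the data shown here, compound 3 `COc1cc(-c2nc(C(c3ccc(F)cc3)c3ccc(F)cc3)sc2CC(=O)O)ccn1` holds the highest of the three numbers so far in an in vitro functional assay on HEK285-7 cells for antagonist activity at prostaglandin D2 receptor 2 (Homo sapiens), read by BRET and beta-arrestin recruitment (on this read-out lower numbers stand for smaller maximal responses and higher numbers for larger maximal responses), where compound 3 gives 60%, though the gaps to the other two lie within the scatter. Compound 1 `Cc1nc(-c2ccc(Cl)cc2)c(CC(=O)O)s1` gives 50% in this assay, and compound 2 `Nc1nc(-c2ccc(Cl)cc2)c(CC(=O)O)s1` gives 50% in this assay. Among the measured compounds shown here, the single measured step, no change at the digits printed from compound 1 to compound 2 (within the scatter), concerns a different position on the core and does not bear on the change considered here. Compound 4 `O=C(O)Cc1sc(C(c2ccc(F)cc2)c2ccc(F)cc2)nc1-c1ccc(Cl)cc1` arises from compound 3 by 4-chlorophenyl in place of 2-methoxypyridin-4-yl on an aromatic carbon. Compounds 1 and 2 both carry the 4-chlorophenyl that enters, and their values in this assay sit within the scatter of the value of compound 3, which carries the 2-methoxypyridin-4-yl that leaves. Nothing measured therefore points to a step beyond the scatter in either direction. On that basis compound 4 is expected to show a number 5 percentage points lower from compound 3 to compound 4 (within the scatter). Compound 4 is estimated at 55% in this assay, within a range from 40% to 70%.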

Compound 4, largest response reached (reported as efficacy), in percent of the reference or control that the assay uses: 80%
Beside the measured number, compound 4's estimate is 25 percentage points below it; the measured number lies above the stated range.
By their numbers in this assay, from the lowest: compounds 1, 2 and 3 (each within the scatter of the next); then compound 4.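

In this assay the exchange of 2-methoxypyridin-4-yl for 4-chlorophenyl gives (a number 20 percentage points higher from compound 3 to compound 4 (beyond the scatter)), the first step among the compounds shown that lies beyond the scatter. Compounds 1 and 2 both carry 4-chlorophenyl at this position, so they could not show that the maximal response depends on the aromatic group here when the large group on the ring stays the same. No measurement shown bears on the reason for this step.

The compounds shown leave open whether the step follows from the chlorine, the ring nitrogen or the methoxy group, which a plain phenyl or a 4-methoxyphenyl at this position could help to separate. They also leave open whether the same exchange has a similar effect with methyl or amino in place of the large group.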